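This account rests on a few compounds, and the source may have more. Where it says the series, first, only, none or still open, it means among the compounds named here.

Measured in a functional assay on L1210 cells (Mus musculus) for cytotoxicity, with a stated time of 48 h; a lower number here means a stronger inhibitor, a higher number a weaker inhibitor:
compound 1 `Clc1ccc(Cc2nn3cc(-c4ccc(Cl)cc4Cl)nc3s2)cc1` gives 247000 nM.
compound 2 `Clc1ccc(Cc2nn3cc(-c4ccccc4)nc3s2)cc1` gives > 250000 nM, which is a limit of the assay and not a number.
compound 3 `Clc1ccc(Cc2nn3c(Br)c(-c4ccc(Cl)cc4Cl)nc3s2)cc1` gives 31000 nM.

The cores of compound 1 and compound 3 differ by bromo in place of hydrogen on an aromatic carbon, a change that gave an 8.0-fold lower number from compound 1 to compound 3 (0.90 log units; beyond the scatter). The change phenyl in place of 2,4-dichlorophenyl on an aromatic carbon gave an at least 1.0-fold higher number from compound 1 to compound 2 (0.00 log units; that floor lies within the scatter), with the value of compound 2 sitting at the limit of > 250000 nM in this assay, at which 1 of the 3 values shown sits, so the true size of that step is not known. Compound 4 `Clc1ccc(Cc2nn3c(Br)c(-c4ccccc4)nc3s2)cc1` carries the same kind of change on the core of compound 3, (phenyl in place of 2,4-dichlorophenyl on an aromatic carbon), the place now being next to the ring atom that bears a bromo group. A weakening is expected, a 3.5-fold higher number from compound 3 to compound 4 (0.55 log units; beyond the scatter), resting on the step of an at least 1.0-fold higher number from compound 1 to compound 2 (0.00 log units; that floor lies within the scatter) and its limit at the limit of > 250000 nM in this assay, at which 1 of the 3 values shown sits. Compound 4 is estimated at 110000 nM, between 40000 nM and 250000 nM.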

Compound 4, half-maximal inhibitory concentration: > 250000 nM
Compound 4 was reported as a limit; the forecaster's own chance of this, stated with the estimate: 25%; at least 2.2-fold (0.35 log units) between middle value and limit.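

In this assay, phenyl in place of 2,4-dichlorophenyl on the bromo-bearing core gave an at least 8.0-fold higher number from compound 3 to compound 4 (0.90 log units; beyond the scatter). Compound 4 stands at a limit of the assay, which is not a number. The change therefore weakens compounds on the core of compound 3 by a step beyond the scatter, but this does not show whether the step carries over from the core of compound 1 at the same size: the same change on two cores in this assay, an at least 1.0-fold higher number (0.00 log units; that floor lies within the scatter) from compound 1 to compound 2 and an at least 8.0-fold higher number (0.90 log units; beyond the scatter) from compound 3 to compound 4; the limit leaves it open whether they differ

From the compounds shown here alone, the bromo step from compound 2 to compound 4 cannot be read, and both compounds stand at the limit: the limit of > 250000 nM in this assay, at which 2 of the 4 values shown sit. Also open is how an amine or a carboxylic acid in place of the bromo group would read on the core of compound 3.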